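The compounds below may be only part of what the source reports. "The series", "measured", "known", "first", "only" and "open" are said of these compounds alone.

Measured so far:
- compound 1, `O=C(/C=C/c1ccccc1)c1ccc(N2CCN(c3ccc([N+](=O)[O-])cc3)CC2)cc1`: 55.4%
- compound 2, `COc1ccc(/C=C/C(=O)c2ccc(N3CCN(c4ccc(Cl)c(Cl)c4)CC3)cc2)cc1OC`: 63.5%

Both of these were tested in a functional assay on the whole organism (strain Kunming) for inhibition, with Mus musculus as the target, with a stated time of 1 h, at a dose of 40 mg/kg by the oral route; on this read-out lower numbers stand for less inhibition and higher numbers for more inhibition at the one dose given (going by the name of the read-out). Compound 1 gives 55.4% and compound 2 gives 63.5%; the gap between these two numbers lies within the usual scatter of repeated measurements, so the data do not separate compound 1 from compound 2, and the two numbers are taken as level.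

The unmeasured compound 3, `Cc1ccc(S(=O)(=O)N2CCN(c3ccc(C(=O)/C=C/c4ccccc4)cc3)CC2)cc1`, shares the core of compound 1 and differs from it in one place: (4-methylphenyl)sulfonyl in place of 4-nitrophenyl on an amine nitrogen in a ring. Going by the values given here, no measured pair tells how such a change moves the read-out in this assay, so the expectation can only rest on the two numbers already seen, which sit close together. The step from compound 1 to compound 3 is therefore expected to be small, likely within the scatter in either direction, a number 3.4 percentage points lower from compound 1 to compound 3 (within the scatter). Compound 3 is estimated at 52%, in a range from 35% to 68%.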

Compound 3, a percentage reported as inhibition, in the whole organism at one dose (the size of the read-out at that dose, not a potency): 30.8%
The estimate for compound 3 lay 21.2 percentage points above the measured number; measured number below the stated range.
By their numbers in this assay, from the lowest: compound 3; then compounds 1 and 2 (each within the scatter of the next).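

In this assay, swapping 4-nitrophenyl for (4-methylphenyl)sulfonyl on the amine nitrogen in the ring gives a number 24.6 percentage points lower from compound 1 to compound 3 (beyond the scatter), the first single change shown to move this read-out clearly. This position is therefore sensitive to what it carries, even though both groups hold one six-membered aromatic ring of carbon only and the same count of hydrogen-bond acceptors. Nothing measured here accounts for the difference.

Still open, on these data alone, is whether the step follows the sulfonyl link or the ring attached to it. A methanesulfonyl group, which keeps the link without the ring, or a 4-methylphenyl group placed directly on the nitrogen, which keeps the ring without the link, would help to separate the two parts.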